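Thiocyanate in place of the terminal amide on an indole chain

This account rests on a few compounds, and the source may have more. Where it says the series, first, only, none or still open, it means among the compounds named here.

Measured compounds:
compound 1, `NC(=O)CCCCc1c[nH]c2ccc(F)cc12`, 39 nM
compound 2, `NCCCCc1c[nH]c2c(F)cccc12`, 6 nM

In an assay on isolated protein (urine) for inhibition of Myeloperoxidase (Homo sapiens), with a stated time of 5 min (a lower number here means a stronger inhibitor, a higher number a weaker inhibitor), compound 1 gives 39 nM, the higher of the two numbers recorded so far. For the measured compounds named here, the nearest measured neighbour is compound 2, which in this assay gives 6 nM, a gap that lies beyond the usual scatter; the two differ in more than one place, so no single step between them is recorded. Compound 3, `N#CSCCCc1c[nH]c2ccc(F)cc12`, is not yet measured. It differs from compound 1 by cyanosulfanyl in place of carbamoylmethyl on a saturated chain carbon, three bonds along the chain from an aromatic carbon. Going by the values given here, no measured pair shows this change, so the size and direction of the step can only be guessed: a modest step in either direction, or none beyond the scatter, is plausible. Compound 3 is expected to give an estimate of 60 nM, within 15 nM to 250 nM, the expected step being a 1.5-fold higher number from compound 1 to compound 3 (0.19 log units; within the scatter).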

Compound 3, half-maximal inhibitory concentration: 5 nM
Estimate against measurement, compound 3: 12-fold (1.08 log units) above, outside the stated range (below it).
By their numbers in this assay, from the lowest: compounds 3 and 2 (each within the scatter of the next); then compound 1.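

In this assay, cyanosulfanyl in place of carbamoylmethyl on a saturated chain carbon, three bonds along the chain from an aromatic carbon, gives a 7.8-fold lower number from compound 1 to compound 3 (0.89 log units; beyond the scatter) and so shows that the end of this chain can change the number markedly, which compounds 1 and 2, differing in more than one place, could not show. The entering group carries no hydrogen-bond donor, whereas the leaving group carries one, so a donor in this group is not required for a low number here. No measurement bears on why the step has this size.

As far as these compounds go, whether the sulfur or the nitrile matters more remains open, and a simple methyl thioether or a nitrile on the same chain would separate the two. From the compounds shown here alone, how a carboxylic acid at this place would compare also remains unknown.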